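The source may report more compounds than this note shows. Statements on the series, on what has been measured and on what is new or still open speak of the compounds shown alone.

Compound 1, with the structure `O=C(O)CCC[C@H](O)[C@@H](/C=C\CCc1ccccc1)Sc1ccc(C(=O)O)cc1`, and compound 2, with the structure `O=C(O)CCC[C@H](O)[C@@H](/C=C\CCCCCc1ccccc1)Sc1ccc(C(=O)O)cc1`, share a core and differ in the length of the saturated chain that carries the terminal phenyl ring. Both were tested in an assay on membranes from lung for binding affinity to cysteinyl leukotriene receptor 1 (Cavia porcellus); on this read-out higher numbers stand for weaker inhibition and lower numbers for stronger inhibition. For compound 1 the two entries in this assay are limits of the assay rather than numbers, given as < 100000 nM; < 100000 nM (2 entries). Compound 2 is the only one of these compounds with a measured number in this assay, where it gives 20000 nM, and a further entry for compound 2 is recorded without a single number. Compound 3, with the structure `O=C(O)CCC[C@H](O)[C@@H](/C=C\CCCCCCCCCc1ccccc1)Sc1ccc(C(=O)O)cc1`, has not yet been measured. It differs from compound 2 by 4-phenylbutyl in place of phenyl on a saturated chain carbon, five bonds along the chain from a double-bonded chain carbon, so that the ring sits further out on a longer saturated chain. Going by the values given here, no measured step connects the two, so only an expectation can be stated. Compound 3 is expected to show a step of a 2.5-fold lower number from compound 2 to compound 3 (0.40 log units; beyond the scatter), towards stronger inhibition, which is modest and lies near the edge of the usual scatter. The estimate for compound 3 in this assay is 8000 nM, within a range from 2000 nM to 40000 nM.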

Compound 3, inhibition constant: 251 nM
The estimate for compound 3 lay 32-fold (1.50 log units) above the measured number; the measured number lies below the stated range.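

Lengthening the group on this saturated chain carbon from phenyl to 4-phenylbutyl gives an 80-fold lower number from compound 2 to compound 3 (1.90 log units; beyond the scatter) in this assay, a large move towards stronger inhibition and well beyond the scatter, so this position responds strongly to how far out the ring sits. Going by these compounds alone, the earlier compounds offered a single number and limits of the assay, so they gave no readable step along the chain; this is the first to show how much the chain length can matter. The change itself is plain, since phenyl and 4-phenylbutyl carry the same six-membered aromatic ring of carbon only, with no hydrogen-bond donors, no hydrogen-bond acceptors and no net charge, and nothing at hand explains why the added saturated carbons have so large an effect.

On these data alone, what remains open is whether the gain builds gradually over intermediate lengths or appears abruptly, and whether a still longer chain would extend it or reverse it. As far as these compounds go, it is equally open whether the chain tolerates an ether oxygen in place of one of its carbons, or whether the terminal phenyl ring can carry a carboxylic acid or an amine without losing this gain.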